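This account rests on a few compounds, and the source may have more. Where it says the series, first, only, none or still open, it means among the compounds named here.

Four compounds from one series are compared in an ADME assay on the whole organism (Mus musculus, strain CD1) for metabolic stability, read by LC-MS, using cassette dosing, with a stated time of 24 h, at a dose of 0.4 mg/kg by the intravenous route; a higher number here means that the compound lasts longer, a lower number that the compound disappears faster. Compound 1 `Cc1cn(-c2cc(NC(=O)c3ccc(C)c(Nc4nccc(-c5ccccc5)n4)c3)cc(N3CCN(C)CC3)c2)cn1` gives 2.21 h in this assay, and compound 2 `Cc1cn(-c2cc(CN3CCC[C@H](N)C3)cc(NC(=O)c3ccc(C)c(Nc4nccc(-c5ccc(F)cc5)n4)c3)c2)cn1` gives 10.8 h. Compound 3 `Cc1cn(-c2cc(NC(=O)c3ccc(C)c(Oc4ccccc4)c3)cc(C(F)(F)F)c2)cn1` gives 2.15 h in this assay, the lowest of the three numbers; the nearest number is that of compound 1, which lies within the scatter of the number for compound 3, while the number for compound 2 stands furthest away, beyond the scatter.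

Compound 4 `Cc1cn(-c2cc(CN3CCC[C@H](N)C3)cc(NC(=O)c3ccc(C)c(Oc4ccccc4)c3)c2)cn1` has not yet been measured in this assay. It differs from compound 3 in one place: (3-aminopiperidin-1-yl)methyl in place of trifluoromethyl on an aromatic carbon. Within the data shown here, no pair of measured compounds differs by this change alone, so no measured step shows its size directly. Among the measured compounds only compound 2 carries the (3-aminopiperidin-1-yl)methyl group, and compound 2 gives 10.8 h in this assay, the highest of the three numbers, so a rise beyond the scatter is expected for compound 4 in this assay. The expected step is a 2.8-fold higher number from compound 3 to compound 4 (0.45 log units; beyond the scatter). Compound 4 is therefore expected to give 6 h in this assay, with a range from 2.5 h to 14 h.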

Compound 4, half-life: 25.7 h
For compound 4 the middle estimate is 4.3-fold (0.63 log units) below the measured one; measured number above the stated range.
By their numbers in this assay, from the lowest: compounds 3 and 1 (each within the scatter of the next); then compound 2; then compound 4.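

In this assay, putting (3-aminopiperidin-1-yl)methyl in place of trifluoromethyl on this aromatic carbon, meta to the 4-methyl-1H-imidazol-1-yl group, gives a 12-fold higher number from compound 3 to compound 4 (1.08 log units; beyond the scatter). Among these compounds, until now the group had been seen only in compound 2, with no partner differing from it by this change alone, so this pair is the first direct reading of the change, and it shows a large rise in half-life with nothing else in the structure altered. Nothing given here accounts for why the half-life rises so far with this change.

One pair cannot tell which part of the entering group goes with the rise: the primary amine, the piperidine ring, the methylene link or the defined stereocentre, and a plain piperidin-1-ylmethyl, a morpholin-4-ylmethyl or the opposite enantiomer of the 3-aminopiperidine at this position would begin to separate these. Going by these compounds, it also remains open whether the same change brings a step of similar size on the core of compound 1, which carries a 4-methylpiperazin-1-yl group at this place.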